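The source may report more compounds than this note shows. Statements on the series, on what has been measured and on what is new or still open speak of the compounds shown alone.

Among the measured compounds shown here, compound 3, with structure `CCCC(Oc1ccc(-n2cc(C)cn2)cc1)c1ccc(C(=O)NCCC(=O)O)cc1`, sits in the middle of the three compounds measured so far in a physicochemical assay for lipophilicity, using the shake flask method, at pH 7.4 (a higher number here means a more lipophilic compound, a lower number a more polar compound), where compound 3 gives 2.1. Compound 1, with structure `CCCC(Oc1ccc(-n2cccn2)cc1)c1ccc(C(=O)NCCC(=O)O)cc1`, gives 1.7 in this assay, and compound 2, with structure `CCCC(Oc1ccc(-n2cc(C(F)(F)F)c(C)n2)cc1)c1ccc(C(=O)NCCC(=O)O)cc1`, gives 2.8. The steps among them are all beyond the scatter: a number 0.40 log units higher from compound 1 to compound 3 (beyond the scatter), a number 1.10 log units higher from compound 1 to compound 2 (beyond the scatter), and a number 0.70 log units lower from compound 2 to compound 3 (beyond the scatter).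

Compound 4, with structure `CCCC(Oc1ccc(-n2cc3c(n2)CCCC3)cc1)c1ccc(C(=O)NCCC(=O)O)cc1`, differs from compound 3 in one place: a group of 9 heavy atoms (7 carbon, 2 nitrogen; one five-membered aromatic ring with 2 hetero atoms, one six-membered non-aromatic ring of carbon only) in place of a group of 6 heavy atoms (4 carbon, 2 nitrogen; one five-membered aromatic ring with 2 hetero atoms), on an aromatic carbon. The nearest comparison is the step from compound 1 to compound 3, where a methyl in place of hydrogen brought a number 0.40 log units higher from compound 1 to compound 3 (beyond the scatter). Here more carbon enters, in the form of a six-membered non-aromatic ring fused to the pyrazole, so a larger rise in this assay than that step is expected, though probably not beyond the rise seen from compound 1 to compound 2, a number 1.10 log units higher from compound 1 to compound 2 (beyond the scatter). The expected change for compound 4 is therefore a number 1.00 log units higher from compound 3 to compound 4 (beyond the scatter). Compound 4 is estimated to give 3.1 in this assay, within a range from 2.6 to 3.6.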

Compound 4, distribution coefficient: 2.7
Beside the measured number, compound 4's estimate is 0.40 log units above it; low and high end bracket the measured number.
By their numbers in this assay, from the lowest: compound 1; then compound 3; then compounds 4 and 2 (each within the scatter of the next).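

On an aromatic carbon para to a large group, the group carrying a six-membered non-aromatic ring of carbon only brings a number 0.60 log units higher from compound 3 to compound 4 (beyond the scatter) in this assay and a number 1.00 log units higher from compound 1 to compound 4 (beyond the scatter), so a carbon-only addition to the 1H-pyrazol-1-yl group moves this number by a clear margin without any fluorine. The comparison with the trifluoromethyl compound gives a number 0.10 log units lower from compound 2 to compound 4 (within the scatter), which means that two quite different groups, one with fluorine and one without, cannot be told apart in this assay at this position. Nothing measured here gives a reason for these steps.

The compounds shown leave open how this assay would respond to a group carrying an amine or a hydroxyl at this position, since every group here contains only carbon, nitrogen and, in compound 2, fluorine. They also leave open whether a five-membered carbon ring in place of the six-membered one would give a step of similar size.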